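The source may hold more compounds than are shown below. What is called first, only, known or untested is meant among the compounds shown, and "the series" means these compounds.

Measured so far in a functional assay on the whole organism (strain Charles Foster albino) for inhibition, with Rattus norvegicus as the target, read by paw edema, with stated times of 30 min and 3 h, at a dose of 50 mg/kg by the oral route; a lower number here means less inhibition, a higher number more inhibition at the dose given (going by the name of the read-out):
- compound 1 `COc1ccc(OC)c(C2CC(c3ccccn3)=NN2c2ccccc2)c1`: 27%
- compound 2 `COc1ccc(OC)c(C2CC(c3ccccn3)=NN2)c1`: 15%
- compound 3 `CN(C)c1ccc(C2CC(c3ccccn3)=NN2c2ccccc2)cc1`: 35%

The values of compound 3 and compound 1 lie within the scatter of each other; compound 3 and compound 2 lie beyond it. The difference between the core of compound 1 and the core of compound 3 is not broken down here.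

One change is measured once: hydrogen in place of phenyl on an amine nitrogen in a ring gives a number 12 percentage points lower from compound 1 to compound 2 (beyond the scatter).

Compound 4 `CN(C)c1ccc(C2CC(c3ccccn3)=NN2)cc1` is not yet measured in this assay. It arises from compound 3 by the same kind of change, (hydrogen in place of phenyl on an amine nitrogen in a ring); around the place, one description reads "the ring atom that bears a group of 9 heavy atoms", the other "the ring atom that bears a large group".

Within the data shown here, for compound 4 a step of a number 12 percentage points lower from compound 3 to compound 4 (beyond the scatter) is expected, resting on a number 12 percentage points lower from compound 1 to compound 2 (beyond the scatter) as the only measured instance of this change. Compound 4 is estimated at 23%, with a likely range from 10% to 36%.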

Compound 4, a percentage reported as inhibition, in the whole organism at one dose (the size of the read-out at that dose, not a potency): 18%
Compound 4: middle estimate off by 5 percentage points, on the high side; measured number inside the range.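

In this assay, hydrogen in place of phenyl on the amine nitrogen in the ring gives a number 17 percentage points lower from compound 3 to compound 4 (beyond the scatter). Across the two cores, the change goes the same way, and the sizes of its steps cannot be told apart: the same change on two cores in this assay, a number 12 percentage points lower (beyond the scatter) from compound 1 to compound 2 and a number 17 percentage points lower (beyond the scatter) from compound 3 to compound 4, 5 percentage points apart, within the scatter of two such steps

This rests on two cores and a single dose, so it does not show that the step would hold on other cores or at other doses.

The compounds shown leave open how other groups on that nitrogen would read, such as methyl, acetyl or a benzyl group, since only phenyl and hydrogen appear there. They also leave open whether an amine or a carboxylic acid on the phenyl group would keep the step.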